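Methoxy to propyl on the amide aryl ring

The source may hold more compounds than are shown below. What is called first, only, known or untested is meant among the compounds shown, and "the series" means these compounds.

Three amides built on one shared core have been run in a functional assay on GTL 16 cells for antiproliferative activity against GTL 16 cell line (Homo sapiens), read by CCK-8 assay, with a stated time of 72 h; on this read-out lower numbers stand for stronger inhibition and higher numbers for weaker inhibition. Compound 1 `COc1ccc(C(=O)Nc2cccc(-c3oc4cc(-c5ccc(F)cc5)ccc4c(=O)c3O)c2)cc1` gives 21100 nM, compound 2 `Cc1ccc(C(=O)Nc2cccc(-c3oc4cc(-c5ccc(F)cc5)ccc4c(=O)c3O)c2)cc1` gives 12900 nM and compound 3 `Cc1cccc(C(=O)Nc2cccc(-c3oc4cc(-c5ccc(F)cc5)ccc4c(=O)c3O)c2)c1` gives 10900 nM. Compound 1 stands highest of the three numbers, but all three lie within the scatter of each other, as shown by a 1.2-fold lower number from compound 2 to compound 3 (0.07 log units; within the scatter). Compound 4 `CCCc1ccc(C(=O)Nc2cccc(-c3oc4cc(-c5ccc(F)cc5)ccc4c(=O)c3O)c2)cc1` differs from compound 1 by propyl in place of methoxy on an aromatic carbon. The change that bears on it most directly is a 1.6-fold lower number from compound 1 to compound 2 (0.21 log units; within the scatter), which also exchanges the methoxy on the same aromatic carbon; the wider exchange a 1.9-fold lower number from compound 1 to compound 3 (0.29 log units; within the scatter) was likewise small. A step no larger than the scatter is therefore expected, if anything toward a lower number: a 1.6-fold lower number from compound 1 to compound 4 (0.21 log units; within the scatter). Compound 4 is estimated at 13000 nM, within 6000 nM to 30000 nM.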

Compound 4, half-maximal inhibitory concentration: 20400 nM
For compound 4 the middle estimate is 1.6-fold (0.20 log units) below the measured one, and the stated range covers the measured number.
By their numbers in this assay, from the lowest: compounds 3, 2, 4 and 1 (each within the scatter of the next).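

In this assay, propyl on the aromatic carbon para to a large group reads the same as methoxy within the scatter: a 1.0-fold lower number from compound 1 to compound 4 (0.01 log units; within the scatter). The propyl compound also stays level with both methyl amides, with a 1.6-fold higher number from compound 2 to compound 4 (0.20 log units; within the scatter) and a 1.9-fold higher number from compound 3 to compound 4 (0.27 log units; within the scatter), so a three-carbon chain at this place adds no step beyond the scatter. No supporting measurement bears on this result.

From the compounds shown here alone, whether an amine, a carboxylic acid or a longer chain at this place would move the number beyond the scatter remains open.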